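The compounds below may be only part of what the source reports. "The series", "measured", "known", "first", "only" and "open" are said of these compounds alone.

In an ADME assay on BCBL1 cells (Homo sapiens) for cytotoxicity, with a stated time of 7 days (on this read-out higher numbers stand for lower toxicity in this test and lower numbers for higher toxicity in this test), compound 1 `Nc1nc(NC2CCCC2)c2ncn(/C=C3/CC3(CO)CO)c2n1` gives 71700 nM. Compound 2 `CC(C)Sc1nc(N)nc2c1ncn2/C=C1/CC1(CO)CO` stands at > 20000 nM, which is a limit and not a number. Compound 3 `CCCCSc1nc(N)nc2c1ncn2/C=C1/CC1(CO)CO` carries butyl in place of isopropyl on a sulfur. Among the compounds with values here, the only measured step bearing on this is a step that the limit leaves unreadable from compound 1 to compound 2, and it has no readable size, with the limit of > 20000 nM in this assay, at which 1 of the 2 values shown sits, as its sole evidence. Within the data shown here, no measured step therefore sizes this change, and no shift beyond the scatter in either direction is expected: a step that the limit leaves unreadable from compound 2 to compound 3 is the estimated step. The estimated value for compound 3 is 30000 nM, with an expected range of 10000 nM to 90000 nM.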

Compound 3, half-maximal cytotoxic concentration: > 20000 nM
Compound 3: a limit, no number (the forecaster's own chance of this, stated with the estimate: 50%); the middle value is on the limit's open side.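

No step can be read from compound 1 to compound 3 or from compound 2 to compound 3: the limit of > 20000 nM in this assay, at which 2 of the 3 values shown sit.

As far as these compounds go, still open in this assay is whether butyl and isopropyl on a sulfur differ at all, and how compound 2 and compound 3 compare with compound 1.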